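Swapping a Nitro for an Amino in Compound 1

The compounds below may be only part of what the source reports. "The series", "measured", "known", "first", "only" and "open" are said of these compounds alone.

Measured in an ADME assay on MT2 cells (Homo sapiens) for cytotoxicity, read by XTT assay, with a stated time of 4 days; on this read-out lower numbers stand for higher toxicity in this test and higher numbers for lower toxicity in this test:
- Compound 1 `CC(=O)/C=C/c1cc(C)c(Oc2cc(Nc3ccc(C#N)cc3)c([N+](=O)[O-])cc2[N+](=O)[O-])c(C)c1`: > 100000 nM (a limit)
- Compound 2 `Cc1cc(/C=C/C#N)cc(C)c1Oc1cc(Nc2ccc(C#N)cc2)c([N+](=O)[O-])cc1[N+](=O)[O-]`: 21700 nM

Compound 1 has only a limit and not a number (the limit of > 100000 nM in this assay, at which 1 of the 2 values shown sits). Compound 3 `CC(=O)/C=C/c1cc(C)c(Oc2cc(Nc3ccc(C#N)cc3)c(N)cc2[N+](=O)[O-])c(C)c1` keeps the core of compound 1 with one change (amino in place of nitro on an aromatic carbon): amino in place of nitro on an aromatic carbon, ortho to a (4-cyanophenyl)amino group. Going by the values given here, only one measured step starts from compound 1 (an at least 4.6-fold lower number from compound 1 to compound 2 (0.66 log units; beyond the scatter)). That step puts cyano in place of acetyl on the chain, a different place from the nitro group, so it bears on this change only loosely. It does show that one change to compound 1 can give a measurable number. Among the compounds with values here, with compound 2 (21700 nM) as the only guide, a step of similar, modest size toward a lower number is expected in this assay. Compound 3 may also stay at the limit. For compound 3 the expected value is 45000 nM within an estimated range of 15000 nM to 100000 nM in this test. This estimate means an expected step (an at least 2.2-fold lower number from compound 1 to compound 3 (0.34 log units; beyond the scatter)).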

Compound 3, half-maximal cytotoxic concentration: 22600 nM
Beside the measured number, compound 3's estimate is 2.0-fold (0.30 log units) above it; the measured number falls inside the stated range.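

In this assay, the nitro group ortho to a (4-cyanophenyl)amino group proves to be a place where one change moves the number: amino in place of nitro gives an at least 4.4-fold lower number from compound 1 to compound 3 (0.64 log units; beyond the scatter). Going by these compounds alone, until this result, the only measured change to compound 1 lay on the chain, so it was unknown whether a change on the aromatic ring could also give a measurable number. The shift here runs toward higher toxicity in this test, and its size has only a lower bound, as compound 1 carries a limit and not a number: the limit of > 100000 nM in this assay, at which 1 of the 3 values shown sits.

Going by these compounds, what stays open is whether the shift comes from the amino group itself or from the loss of the nitro group, a question that a hydroxyl group, a methylamino group or a plain hydrogen at this position could help to settle. Also open, on these data alone, is whether amino in place of the remaining nitro group, which sits meta to this position, would give a step of similar size.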